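Amide substituent changes on the shared core

The compounds below may be only part of what the source reports. "The series", "measured", "known", "first", "only" and "open" are said of these compounds alone.

Measured compounds:
compound 1 `CCn1c(C(=O)NCCCN(C)C)ccc1C(CC)(CC)c1ccc(OCCC(O)(CC)CC)c(C)c1` — 5 nM
compound 2 `CCC(C)C(NC(=O)c1ccc(C(CC)(CC)c2ccc(OCCC(O)(CC)CC)c(C)c2)n1CC)C(=O)OC` — > 10000 nM

Notes. In an assay on cells for agonist activity at vitamin D3 receptor (Homo sapiens), with a stated time of 96 h (on this read-out higher numbers stand for an effect only at larger amounts of compound and lower numbers for an effect already at smaller amounts), compound 1 gives 5 nM. For compound 2 the assay reports only a limit, > 10000 nM, so compound 2 sits at the edge of what this assay can resolve, not at a number. Among the measured compounds shown here, the step of an at least 2000-fold higher number from compound 1 to compound 2 (3.30 log units; beyond the scatter) is the only measured step on the amide-type nitrogen, and one of its two values is a limit: the limit of > 10000 nM in this assay, at which 1 of the 2 values shown sits.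

Compound 3 `CCn1c(C(=O)N(C)CC(=O)O)ccc1C(CC)(CC)c1ccc(OCCC(O)(CC)CC)c(C)c1` has not been measured. It differs from compound 2 in a group of 6 heavy atoms (3 carbon, 1 nitrogen, 2 oxygen; no ring) in place of a group of 10 heavy atoms (7 carbon, 1 nitrogen, 2 oxygen; no ring), on a carbonyl carbon. For the measured compounds named here, the group entering is smaller than the one leaving, and nearer in size to the group on compound 1, but it carries a carboxylic acid that neither measured compound has, so no measured step covers this change directly. Going by the values given here, the only bearing step is an at least 2000-fold higher number from compound 1 to compound 2 (3.30 log units; beyond the scatter), which shows the larger substituent moving the number to the limit. On that basis the expected step from compound 2 is an at least 33-fold lower number from compound 2 to compound 3 (1.52 log units; beyond the scatter), toward a lower number in this assay. The estimate for compound 3 in this assay is 300 nM, within 10 nM to 10000 nM, with a real chance that only a limit is reported.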

Compound 3, half-maximal effective concentration: 89 nM
Estimate against measurement, compound 3: 3.4-fold (0.53 log units) above, and the stated range covers the measured number.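

In this assay, (carboxymethyl)(methyl)amino on the carbonyl carbon gives an at least 110-fold lower number from compound 2 to compound 3 (2.05 log units; beyond the scatter) and so returns the series to a readable value, which shows that this position does not depend on the (3-(dimethylamino)propyl)amino group of compound 1 for a measurable effect. The same replacement, read against compound 1, gives an 18-fold higher number from compound 1 to compound 3 (1.25 log units; beyond the scatter) and leaves compound 1 with the lowest number of the three, so the position tolerates an end group other than dimethylamino, but at a clear cost in this read-out. For compound 2 the value > 10000 nM is a limit and not a number, so the true size of the first step remains a bound: the limit of > 10000 nM in this assay, at which 1 of the 3 values shown sits.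

Between compound 1 and compound 3, the chain length, the end group and the methyl on the amide nitrogen all change together, so the share of the step belonging to each stays open. A carboxymethylamino group that keeps the amide hydrogen, or a 3-carboxypropylamino chain, would begin to separate these contributions.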